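From 2-chlorophenyl to 2-methylphenyl: notes on compound 3

The source may hold more compounds than are shown below. What is called first, only, known or untested is meant among the compounds shown, and "the series" means these compounds.

Measured in a physicochemical assay for lipophilicity; a higher number here means a more lipophilic compound, a lower number a more polar compound:
- compound 1 `C[C@H]1CC[C@@H]2[C@@H](OC(=O)[C@]23CC(c2ccc(N(C)C)cc2)=NO3)[C@]2(C)C(=O)C=C[C@@]12O`: 1.51
- compound 2 `COc1cc(C2=NO[C@]3(C2)C(=O)O[C@@H]2[C@H]3CC[C@H](C)[C@]3(O)C=CC(=O)[C@@]23C)ccc1O`: 0.75
- compound 3 `C[C@H]1CC[C@@H]2[C@@H](OC(=O)[C@]23CC(c2ccccc2Cl)=NO3)[C@]2(C)C(=O)C=C[C@@]12O`: 2.09

Among these three, compound 3 stands highest, with compound 1 nearest and compound 2 furthest, both lower beyond the scatter. Next is compound 4 `Cc1ccccc1C1=NO[C@]2(C1)C(=O)O[C@@H]1[C@H]2CC[C@H](C)[C@]2(O)C=CC(=O)[C@@]12C`, which differs from compound 3 as follows: methyl in place of chloro on an aromatic carbon. This is methyl in place of chloro on an aromatic carbon, ortho to a large group.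

Two measured steps reach compound 3: the modest a number 0.58 log units higher from compound 1 to compound 3 (beyond the scatter) and the large a number 1.34 log units higher from compound 2 to compound 3 (beyond the scatter). Both exchange the whole substituted phenyl group, as does the modest a number 0.76 log units lower from compound 1 to compound 2 (beyond the scatter). None exchanges chloro for methyl alone, so these steps show how far this assay has moved in this series, but they do not give the direction of the present change. That change is much smaller, with one heavy atom leaving and one entering, so no step beyond the scatter is expected. The expected step is a number 0.14 log units lower from compound 3 to compound 4 (within the scatter), and its slight downward direction is a judgement these data do not test. The starting point is compound 3 at 2.09. For compound 4 the estimated value is 1.95, with an expected range of 1.6 to 2.3.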

Compound 4, partition coefficient: 1.86
Compound 4: the middle estimate sits 0.09 log units above what was measured, and the stated range covers the measured number.
By their numbers in this assay, from the lowest: compound 2; then compound 1; then compounds 4 and 3 (each within the scatter of the next).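

In this assay, the exchange of chloro for methyl on this aromatic carbon, ortho to a large group, gives the series its first reading of a change confined to one atom at this place, and the step is a number 0.23 log units lower from compound 3 to compound 4 (within the scatter). The earlier steps shown here all exchanged the whole substituted phenyl group, and the new whole-group steps, a number 1.11 log units higher from compound 2 to compound 4 (beyond the scatter) and a number 0.35 log units higher from compound 1 to compound 4 (beyond the scatter), show that compound 4, like compound 3, stands clear of both compound 1 and compound 2 beyond the scatter. No measured evidence here bears on why chloro and methyl at this place give values within the scatter of each other.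

On these data alone, it remains open whether this closeness extends to other groups on the same aromatic carbon, such as an ethyl chain, an amine or a carboxylic acid, any of which might leave compound 3 by a step beyond the scatter. The compounds shown also do not settle whether chloro and methyl stay this close in any read-out other than this assay.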